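Swapping the heterocycle on the sulfur: compound 3 to compound 4

The compounds below may be only part of what the source reports. "The series", "measured", "known", "first", "only" and "open" are said of these compounds alone.

Measured compounds in a functional assay on SW480 cells (Homo sapiens) for cytotoxicity, read by MTT assay, with a stated time of 72 h; on this read-out higher numbers stand for weaker inhibition and lower numbers for stronger inhibition:
- compound 1, `Cc1nnc(Sc2coc3ccccc3c2=O)s1`: > 50000 nM, a limit of the assay rather than a number
- compound 2, `Cc1cc(C)n2nc(SCc3nnc(SCc4coc5ccccc5c4=O)n3-c3ccccc3)nc2n1`: 12400 nM
- compound 3, `Nc1nc(SCc2coc3ccccc3c2=O)n[nH]1`: 21400 nM

Compound 3 holds the highest of the two numbers in this assay; its nearest neighbour is compound 2, and that gap lies within the scatter. Compound 4, `Cc1nnc(SCc2coc3ccccc3c2=O)s1`, is not yet measured. It differs from compound 3 in one place: 5-methyl-1,3,4-thiadiazol-2-yl in place of 5-amino-1H-1,2,4-triazol-3-yl on a sulfur. Within the data shown here, no step between measured compounds covers this change, so the expected step is small, in either direction or none beyond the scatter. The estimate for compound 4 in this assay is 28000 nM, spanning 9000 nM to 80000 nM, which means an expected step of a 1.3-fold higher number from compound 3 to compound 4 (0.12 log units; within the scatter).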

Compound 4, half-maximal inhibitory concentration: 1000 nM
Estimate against measurement, compound 4: 28-fold (1.45 log units) above, and the stated range ends above it.
By their numbers in this assay, from the lowest: compound 4; then compounds 2 and 3 (each within the scatter of the next). At a limit, above all of these: compound 1.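

On a sulfur whose other neighbour is a saturated chain carbon, this position proves sensitive to the ring it carries: in this assay, 5-methyl-1,3,4-thiadiazol-2-yl in place of 5-amino-1H-1,2,4-triazol-3-yl gives a 21-fold lower number from compound 3 to compound 4 (1.33 log units; beyond the scatter) even though the heavy-atom count stays the same and the hydrogen-bond donors are lost. Compound 1 carries the same 5-methyl-1,3,4-thiadiazol-2-yl on a sulfur without that chain carbon, and its > 50000 nM is a limit of the assay. Nothing shown gives a cause for the step. From the compounds shown here alone, whether an amine or a longer chain in place of the methyl would hold this gain remains open.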